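This account rests on a few compounds, and the source may have more. Where it says the series, first, only, none or still open, it means among the compounds named here.

Measured compounds:
compound 1 `CC(=O)NC(=O)Nc1cccc(NC(=O)CBr)c1` — 3200 nM in a functional assay on CCRF-CEM cells (Homo sapiens) for cytotoxicity, read by MTT assay, with a stated time of 72 h; on this read-out lower numbers stand for stronger inhibition and higher numbers for weaker inhibition
compound 2 `CC(=O)NC(=O)Nc1cccc(NC(=O)C(C)Br)c1` — 10600 nM in this assay

Among the measured compounds shown here, compound 1 gives the lowest of the two numbers measured in this assay; its nearest neighbour is compound 2, and the only measured step in the set, a 3.3-fold higher number from compound 1 to compound 2 (0.52 log units; beyond the scatter), is the change of methyl in place of hydrogen on a saturated chain carbon bound to a bromine atom and a carbonyl carbon.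

Compound 3 `O=C(CBr)NC(=O)Nc1cccc(NC(=O)CBr)c1` has not yet been measured. It differs from compound 1 by bromo in place of hydrogen on a saturated chain carbon bound to a carbonyl carbon; cut one bond further out this reads acetyl to (bromomethyl)carbonyl, so compound 3 carries two bromomethylcarbonyl groups where compound 1 carries one. For the measured compounds named here, no measured step covers bromo in place of hydrogen on a saturated chain carbon bound to a carbonyl carbon. The step of a 3.3-fold higher number from compound 1 to compound 2 (0.52 log units; beyond the scatter) concerns a different change and does not transfer directly. Going by the values given here, the only guide is that compound 1, the single bromomethylcarbonyl compound, stands lower than compound 2, so a second such group is expected to leave the number where it is or move it lower by a modest step at most in this assay. For compound 3 the expected step from compound 1 is a 1.8-fold lower number from compound 1 to compound 3 (0.25 log units; within the scatter). Compound 3 is estimated at 1800 nM, within 600 nM to 5000 nM.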

Compound 3, half-maximal inhibitory concentration: 560 nM
The estimate for compound 3 lay 3.2-fold (0.51 log units) above the measured number; measured number outside the range, below it.
By their numbers in this assay, from the lowest: compound 3; then compound 1; then compound 2.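

In this assay the acetyl group of compound 1 proves to be a position where a single change moves the number: bromo in place of hydrogen on a saturated chain carbon bound to a carbonyl carbon gives a 5.7-fold lower number from compound 1 to compound 3 (0.76 log units; beyond the scatter), a step in the opposite direction from the only earlier one. That earlier step, a 3.3-fold higher number from compound 1 to compound 2 (0.52 log units; beyond the scatter), was read on the carbon already bound to a bromine atom, so it said nothing about the acetyl group, and the series now shows that a second bromomethylcarbonyl group lowers the number rather than leaving it in place. No supporting measurement accompanies this result, so the step stands as an observation without an explanation.

The compounds shown do not tell whether the bromine atom itself is required at this position, since a chloro group, a hydroxy group or an amine on the same carbon, or a longer chain in place of bromomethyl, would be needed to separate it from other replacements. As far as these compounds go, it also remains open whether methyl in place of hydrogen would raise the number to the same extent when placed on the bromomethyl group of compound 3.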